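Compound 1 to compound 4: a phenoxy step

A few compounds are considered here, and "the series" means these few. Any claim that something is new, unique, unknown or untested is made for them only; others in the source may bear on it.

Within the data shown here, in a functional assay on DU-145 cells (Homo sapiens) for inhibition, read by CCK-8 assay, with a stated time of 72 h (on this read-out higher numbers stand for weaker inhibition and lower numbers for stronger inhibition), compound 1 `O=C(/C=C/c1cccnc1)NCCCCCCc1cccc(S(=O)(=O)Nc2ccccc2)c1` gives 6.73 nM, the lowest of the three numbers measured so far. Compound 3 `Cc1cccc(NS(=O)(=O)c2cccc(CCCCCCNC(=O)/C=C/c3cccnc3)c2)c1` gives 41.7 nM, and compound 2 `O=C(/C=C/c1cccnc1)NCCCCCCCc1cccc(S(=O)(=O)Nc2ccccc2)c1` gives 429 nM. Compound 1 is therefore a high starting point, and the measured numbers all lie on the weaker side of it.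

Compound 4 `O=C(/C=C/c1cccnc1)NCCCCCCc1cccc(S(=O)(=O)Nc2ccc(Oc3ccccc3)cc2)c1` departs from compound 1 by phenoxy in place of hydrogen on an aromatic carbon, para to a large group.

Among the measured compounds shown here, one measured step bears on this change: a 6.2-fold higher number from compound 1 to compound 3 (0.79 log units; beyond the scatter), a modest loss beyond the scatter, for methyl in place of hydrogen on an aromatic carbon. Compound 2 does not involve a substitution of this kind and gives no guide to its size. For the measured compounds named here, that single step is thin evidence, and no phenoxy example has been measured. Phenoxy is also a far larger entrant than methyl, so the expectation is a step of similar or somewhat greater size, towards weaker inhibition, with wide uncertainty.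

The expected change is an 8.9-fold higher number from compound 1 to compound 4 (0.95 log units; beyond the scatter). For compound 4 the estimated value is 60 nM, with an expected range of 10 nM to 400 nM.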

Compound 4, half-maximal inhibitory concentration: 50.9 nM
Beside the measured number, compound 4's estimate is 1.2-fold (0.07 log units) above it; the range from low to high includes it.
By their numbers in this assay, from the lowest: compound 1; then compounds 3 and 4 (each within the scatter of the next); then compound 2.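

In this assay, among these compounds, the step of a 7.6-fold higher number from compound 1 to compound 4 (0.88 log units; beyond the scatter) is the only reading at the aromatic carbon para to a large group. It shows that phenoxy, with its 7 heavy atoms and its six-membered aromatic ring of carbon only, brings a modest loss at this place and leaves inhibition in place. Compound 1, with hydrogen, keeps the lowest number, so neither aromatic replacement shown, the methyl of compound 3 or the phenoxy of compound 4, improves on hydrogen, and no evidence bearing on this step accounts for the loss.

On these data alone, whether the loss at this place tracks the size of the entering group stays open, and a small group such as fluorine or methoxy on the same carbon would test that directly against the phenoxy of compound 4. Also open, as far as these compounds go, is how this carbon responds to an amine or a carboxylic acid, or to benzyloxy, which sets the outer ring one carbon further out than phenoxy does.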